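The compounds below may be only part of what the source reports. "The series", "measured", "known", "first", "only" and "open" are said of these compounds alone.

Compound 1 `Cc1c(-c2ccc(Cc3ccc(C(C)(C)C)cc3)cc2)[nH]c2cccc(F)c2c1=O`: > 5000 nM
Compound 2 `Cc1c(-c2ccc(Cc3ccc(S(=O)(=O)C(F)(F)F)cc3)cc2)[nH]c2cccc(F)c2c1=O`: > 2500 nM

In an ADME assay on Huh7.5.1 cells (Homo sapiens) for cytotoxicity, read by WST assay, with a stated time of 48 h (a lower number here means that less compound is tolerated, a higher number that more compound is tolerated), compound 1 gives > 5000 nM, which is a limit of the assay and not a number. Compound 2 gives > 2500 nM, and this too is only a limit. Neither compound therefore has an exact value to build on.

Compound 3 `CN=S(=O)(c1ccc(Cc2ccc(-c3[nH]c4cccc(F)c4c(=O)c3C)cc2)cc1)C(F)(F)F` has not yet been measured. It differs from compound 2 at one place: a group of 8 heavy atoms (2 carbon, 1 nitrogen, 1 oxygen, 3 fluorine, 1 sulfur; no ring) in place of a group of 7 heavy atoms (1 carbon, 2 oxygen, 3 fluorine, 1 sulfur; no ring), on an aromatic carbon. The (trifluoromethyl)sulfonyl group leaves, and a group with no common name enters on an aromatic carbon, para to a large group.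

Among the compounds with values here, the only measured step that bears on this is a step that the two limits leave unreadable from compound 1 to compound 2, also at this place on the molecule. It has no readable size, so it offers no basis for expecting a real shift. No change beyond the usual scatter is expected, and compound 3 may well return a limit too. The expected step is a step that the limit leaves unreadable from compound 2 to compound 3. For compound 3 the estimated value is 5000 nM, within an expected range of 2000 nM to 15000 nM.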

Compound 3, half-maximal cytotoxic concentration: > 10000 nM
Compound 3: no number, only a limit (the forecaster's own chance of this, stated with the estimate: 75%); middle value at least 2.0-fold (0.30 log units) from the limit.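

In this assay, within the data shown here, compound 3 gives only a limit, as do compound 1 and compound 2, and no step among compound 1, compound 2 and compound 3 can be read. The compounds shown leave open the concentration at which each becomes toxic to these cells, and whether swapping the group on this aromatic carbon changes it.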